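Carbamate Re-entry on the Sulfonamide Side Chain

This account rests on a few compounds, and the source may have more. Where it says the series, first, only, none or still open, it means among the compounds named here.

Compound 1: `CC(C)NCCS(=O)(=O)NC(=O)c1ccc(Nc2nc(NC3(c4ccc(Cl)cc4)CC3)nc(OCC(F)(F)F)n2)cc1` with 100%
Compound 2: `CC(C)(C)OC(=O)NCCS(=O)(=O)NC(=O)c1ccc(Nc2nc(NC3(c4ccc(Cl)cc4)CC3)nc(OCC(F)(F)F)n2)cc1` with 93%
Compound 3: `CCS(=O)(=O)NC(=O)c1ccc(Nc2nc(NC3(c4ccc(Cl)cc4)CC3)nc(OCC(F)(F)F)n2)cc1` with 85%

Three compounds sharing one core have been run in an ADME assay on microsomes from liver (Rattus norvegicus) for metabolic stability, with a stated time of 10 min; on this read-out higher numbers stand for a more stable compound and lower numbers for a less stable compound. Compound 3 stands lowest of the three; its nearest neighbour is compound 2, and the step of a number 8 percentage points lower from compound 2 to compound 3 (within the scatter) is within the scatter, while the step of a number 15 percentage points lower from compound 1 to compound 3 (beyond the scatter) is beyond it, though modest. The step of a number 7 percentage points lower from compound 1 to compound 2 (within the scatter) is within the scatter.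

Compound 4, `CC(C)OC(=O)NCCS(=O)(=O)NC(=O)c1ccc(Nc2nc(NC3(c4ccc(Cl)cc4)CC3)nc(OCC(F)(F)F)n2)cc1`, has not yet been measured in this assay. It differs from compound 3 by (isopropoxycarbonyl)amino in place of hydrogen on a saturated chain carbon, two bonds along the chain from a sulfonyl sulfur. Among the measured compounds shown here, the most relevant measured step is the one from compound 2 to compound 3, where the closely related (tert-butoxycarbonyl)amino group was removed at the same place with a change within the scatter; the step from compound 1 to compound 3 suggests that re-adding a group there may raise the number modestly. Compound 4 is therefore expected to give 92%, between 82% and 100%, an estimated step of a number 7 percentage points higher from compound 3 to compound 4 (within the scatter) that may or may not exceed the scatter.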

Compound 4, percent of the compound remaining: 73%
For compound 4 the middle estimate is 19 percentage points above the measured one, and the stated range ends above it.
By their numbers in this assay, from the lowest: compound 4; then compounds 3, 2 and 1 (each within the scatter of the next, the first and the last beyond it).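

In this assay the saturated chain carbon two bonds along the chain from the sulfonyl sulfur does not treat every carbamate alike: (isopropoxycarbonyl)amino in place of hydrogen gives a number 12 percentage points lower from compound 3 to compound 4 (beyond the scatter) while the (tert-butoxycarbonyl)amino group had stayed within the scatter of hydrogen. Hydrogen in place of a single methyl on the saturated chain carbon bound to the carbamate oxygen gives a number 20 percentage points lower from compound 2 to compound 4 (beyond the scatter) and is enough to separate the two carbamates. Isopropoxycarbonyl in place of isopropyl gives a number 27 percentage points lower from compound 1 to compound 4 (beyond the scatter) whereas tert-butoxycarbonyl gave a number 7 percentage points lower from compound 1 to compound 2 (within the scatter) on the same nitrogen.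

Going by these compounds, whether a methyl carbamate, an ethyl carbamate, an acetamide or a free primary amine at this place would follow compound 2 or compound 4 stays open. The data at hand offer nothing that explains the gap between the two carbamates.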